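What a 1,3,4-thiadiazol-2-yl group may do to compound 2

This account rests on a few compounds, and the source may have more. Where it says the series, first, only, none or still open, it means among the compounds named here.

Compound 1 `Nc1nccn2c1c(-c1ccc3ccc(-c4ccccc4)nc3c1F)nc2[C@H]1CC[C@H](C(=O)O)CC1` and compound 2 `Nc1nccn2c1c(-c1ccc3ccc(-c4ccccc4)nc3c1F)nc2[C@H]1CC[C@H](C(N)=O)CC1` share one core and differ only on a carbonyl carbon. In an in vivo ADME assay on the whole organism for pharmacokinetics, with Mus musculus as the target, at a dose of 25 mg/kg by the oral route (a higher number here means more compound in the circulation at the dose given, a lower number less compound in the circulation), compound 1 gives 5500 nM and compound 2 gives 1900 nM, so compound 2 holds the lower of the two numbers.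

The unmeasured compound 3 `Nc1nccn2c1c(-c1ccc3ccc(-c4ccccc4)nc3c1F)nc2[C@H]1CC[C@H](C(=O)Nc2nncs2)CC1` keeps all of compound 2 except for one change: 1,3,4-thiadiazol-2-yl in place of hydrogen on an amide-type nitrogen. Here 1,3,4-thiadiazol-2-yl stands in place of hydrogen on an amide-type nitrogen, whose other neighbour is the carbonyl carbon.

Within the data shown here, only one measured step bears on this: a 2.9-fold lower number from compound 1 to compound 2 (0.46 log units; beyond the scatter), with amino in place of hydroxy on a carbonyl carbon. That step was modest but beyond the scatter. Among the measured compounds shown here, it is a different change from the one in compound 3, and no measured compound carries a ring on this nitrogen, so it offers only weak guidance. Taking it as the sole clue, a further modest fall is expected. The expected change is a 2.4-fold lower number from compound 2 to compound 3 (0.38 log units; beyond the scatter), an uncertain estimate.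

For compound 3 the estimated value is 800 nM, within an expected range from 200 nM to 3000 nM.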

Compound 3, maximal plasma concentration: 130 nM
Compound 3: middle estimate off by 6.2-fold (0.79 log units), on the high side; measured number outside the range, below it.
By their numbers in this assay, from the lowest: compound 3; then compound 2; then compound 1.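

In this assay, among these compounds, putting 1,3,4-thiadiazol-2-yl in place of hydrogen on the amide-type nitrogen gives a 15-fold lower number from compound 2 to compound 3 (1.16 log units; beyond the scatter) and counts as a large step, whereas the only earlier change at this end of the molecule, a 2.9-fold lower number from compound 1 to compound 2 (0.46 log units; beyond the scatter) and modest in size, gave no sign of a drop on this scale. Replacing hydroxy on the carbonyl carbon with (1,3,4-thiadiazol-2-yl)amino gives a 42-fold lower number from compound 1 to compound 3 (1.63 log units; beyond the scatter) and is also large, so across these three compounds, all sharing one core, this single place can move the maximal plasma concentration widely at the same oral dose. No measurement shown here accounts for the size of this fall.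

The compounds shown leave open whether the fall belongs to this particular ring or would follow any group on this nitrogen: a methyl group, a phenyl ring or a longer chain ending in an amine on the same nitrogen would help separate those readings. They also leave open how the compounds behave over time in the circulation, as a maximal concentration alone does not describe the whole plasma curve.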